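This account rests on a few compounds, and the source may have more. Where it says the series, first, only, none or still open, it means among the compounds named here.

Of the compounds shown here, three have been measured in a functional assay on WiDr cells (Homo sapiens) for inhibition, read by sulforhodamine B assay, with a stated time of 48 h; a lower number here means a stronger inhibitor of growth, a higher number a weaker inhibitor of growth. Compound 1 `COC(=O)[C@@]1(C)CCC=C2[C@@H]1CC[C@@H](C)[C@]2(C)Cc1c[nH]c2c(C)cccc12` gives 26000 nM in this assay. Compound 2 `COC(=O)[C@@]1(C)CCC=C2[C@@H]1CC[C@@H](C)[C@]2(C)Cc1c(C=O)[nH]c2ccccc12` gives 20000 nM in this assay. Compound 3 `COC(=O)[C@@]1(C)CC[C@@H]2C3=C1CC[C@@H](C)[C@]3(C)C[C@@H]1c3ccccc3N[C@H]21` gives 50000 nM in this assay, the highest of the three numbers: the gap to compound 1 lies within the usual scatter, while the gap to compound 2 lies beyond it, so compound 2 inhibits growth more strongly than compound 3, and compound 1 and compound 3 cannot be told apart.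

Compound 4 `COC(=O)[C@@]1(C)CC[C@@H]2C3=C1CC[C@@H](C)[C@]3(C)C[C@@H]1c3cc(Cl)ccc3N[C@H]21` is the next compound. It differs from compound 3 by chloro in place of hydrogen on an aromatic carbon — chloro in place of hydrogen on an aromatic carbon. For the measured compounds named here, no measured pair shows the effect of this change in this assay, so the step can only be guessed. A small step is expected, with no firm direction, most likely within the scatter. Compound 4 is therefore estimated at 35000 nM in this assay, with a range from 12000 nM to 100000 nM. This estimate means a step of a 1.4-fold lower number from compound 3 to compound 4 (0.15 log units; within the scatter) in this assay.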

Compound 4, concentration for 50% growth inhibition: 48000 nM
Compound 4: the middle estimate sits 1.4-fold (0.14 log units) below what was measured; the measured number falls inside the stated range.
By their numbers in this assay, from the lowest: compounds 2, 1, 4 and 3 (each within the scatter of the next, the first and the last beyond it).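

For the compounds shown here, this is the first pair of compounds that differ in one place, and in this assay chloro in place of hydrogen on the aromatic carbon gives a 1.0-fold lower number from compound 3 to compound 4 (0.02 log units; within the scatter). Compound 3 and compound 4 therefore cannot be told apart, so on this core a single chlorine at this carbon, meta to a fused ring and para to a fused ring, leaves growth inhibition indistinguishable from that with hydrogen. No measurement shown bears on the reason for this result.

Still open, going by these compounds, is whether a different group at this carbon, such as a methoxy group, an amine or a carboxylic acid, would separate from hydrogen in this assay. Also open, on these data alone, is whether chloro on another carbon of this aromatic ring would give the same result as it does here.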